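A few compounds are considered here, and "the series" means these few. Any claim that something is new, unique, unknown or untested is made for them only; others in the source may bear on it.

In a functional assay on HT-29 cells (Homo sapiens) for cytotoxicity, read by sulforhodamine B assay, with a stated time of 48 h (a lower number here means a stronger inhibitor, a higher number a weaker inhibitor), compound 1, `CCCc1ccccc1NS(=O)(=O)c1cccc(NC(=O)NCCCCl)c1`, gives 15000 nM. Compound 2, `CCNC(=O)Nc1cccc(S(=O)(=O)Nc2ccccc2CC)c1`, gives 15000 nM in this assay, which is level with compound 1 at the digits shown, and the two values lie within the scatter of each other. Compound 3, `CCCc1ccccc1NS(=O)(=O)c1cccc(NC(=O)NCC)c1`, has not yet been measured in this assay. It differs from compound 2 by methyl in place of hydrogen on a saturated chain carbon, two bonds along the chain from an aromatic carbon. No measured pair in this set makes this same change, so the size of the step is not known from the numbers shown. Since compound 1 gives 15000 nM and compound 2 gives 15000 nM, both at the same level, the step of no change at the digits printed from compound 2 to compound 3 (within the scatter) is expected to be small, in no clear direction, and not beyond the scatter. Compound 3 is therefore estimated to give 15000 nM in this assay, within a range from 7000 nM to 32000 nM.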

Compound 3, half-maximal inhibitory concentration: 41000 nM
Compound 3: the middle estimate sits 2.7-fold (0.44 log units) below what was measured, outside the stated range (above it).
By their numbers in this assay, from the lowest: compounds 1 and 2 (each within the scatter of the next); then compound 3.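

In this assay, this position on the chain is sensitive to a small change: methyl in place of hydrogen on a saturated chain carbon, two bonds along the chain from an aromatic carbon, gives a 2.7-fold higher number from compound 2 to compound 3 (0.44 log units; beyond the scatter), a modest step beyond the scatter. At the other chain, hydrogen in place of chloromethyl on a saturated chain carbon, two bonds along the chain from an amide-type nitrogen, gives a 2.7-fold higher number from compound 1 to compound 3 (0.44 log units; beyond the scatter), so compound 3 carries the higher number in both pairs. Nothing available here accounts for either step.

On these data alone, whether a longer chain such as butyl at this position would raise the number further remains open. So does whether an amine or a carboxylic acid at the end of the other chain would bring it back down.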